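Swapping a fluorobenzyl amine for a piperidinylethyl amine

A few compounds are considered here, and "the series" means these few. Any claim that something is new, unique, unknown or untested is made for them only; others in the source may bear on it.

Compound 3 `CCN(Cc1ccc(F)cc1)c1ccc(C(=O)N2CCc3ccc(OS(N)(=O)=O)cc3C2)cc1` stands second highest of three numbers in an assay on HEK293 cells for inhibition of Steryl-sulfatase (Homo sapiens), tested at 0.1 uM (a higher number here means a stronger effect of the compound at the concentration tested, a lower number a weaker effect), where compound 3 gives 69.1%. The nearest value belongs to compound 2 `CCN(Cc1ccc(Br)cc1)c1ccc(C(=O)N2CCc3ccc(OS(N)(=O)=O)cc3C2)cc1` with 78.2%. That gap, a number 9.1 percentage points lower from compound 2 to compound 3 (within the scatter), lies within the scatter. Far below sits compound 1 `CN(C)CCN(CCN(C)C)c1ccc(C(=O)N2CCc3ccc(OS(N)(=O)=O)cc3C2)cc1` at 3.8%. Compound 4 `CN(CCN1CCCCC1)c1ccc(C(=O)N2CCc3ccc(OS(N)(=O)=O)cc3C2)cc1` differs from compound 3 by methyl(2-(piperidin-1-yl)ethyl)amino in place of ethyl(4-fluorobenzyl)amino on an aromatic carbon. Among the compounds with values here, the steps that bear on this run the opposite way: a number 74.4 percentage points higher from compound 1 to compound 2 (beyond the scatter) and a number 65.3 percentage points higher from compound 1 to compound 3 (beyond the scatter), both large, each replacing an amine bearing two dimethylaminoethyl chains with an ethyl(benzyl)amine. Because compound 1 gave 3.8% with an amine of related build, a large drop is expected, a number 54.1 percentage points lower from compound 3 to compound 4 (beyond the scatter). Compound 4 is therefore estimated at 15%, ranging from 0% to 45%.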

Compound 4, a percentage reported as inhibition, at one concentration (the size of the read-out at that concentration, not a potency): 0.3%
The estimate for compound 4 lay 14.7 percentage points above the measured number, within the range that was stated.
By their numbers in this assay, from the lowest: compounds 4 and 1 (each within the scatter of the next); then compounds 3 and 2 (each within the scatter of the next).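

In this assay the methyl(2-(piperidin-1-yl)ethyl)amino group removes nearly all the effect the benzyl amines carry at this position, with a number 68.8 percentage points lower from compound 3 to compound 4 (beyond the scatter) and a number 77.9 percentage points lower from compound 2 to compound 4 (beyond the scatter) as the two large steps. Against the open-chain amine the result is a number 3.5 percentage points lower from compound 1 to compound 4 (within the scatter) and so shows no separation, which means a terminal piperidine ring and two dimethylaminoethyl chains read alike here. Nothing measured on these compounds accounts for the loss.

The compounds leave open whether the loss follows the departure of the fluorobenzyl ring or the arrival of the piperidine nitrogen, since both change in one step. A cyclohexylethyl amine, with carbon in place of that nitrogen, would separate the two.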